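From trifluoromethyl to methoxy on an aromatic carbon

The source may report more compounds than this note shows. Statements on the series, on what has been measured and on what is new or still open speak of the compounds shown alone.

Measured in a functional assay on KB cells (Homo sapiens) for antiproliferative activity, read by sulforhodamine B assay, with a stated time of 3 days; a higher number here means that more compound is needed for the effect, a lower number that less compound is needed:
- compound 1 `CCC1=C(O)c2c(oc(-c3ccc(C)cc3)cc2=O)C(CC)(CC)C1=O`: 39.2 uM
- compound 2 `CCC1=C(O)c2c(oc(-c3ccc(COC)cc3)cc2=O)C(CC)(CC)C1=O`: > 52.4 uM (a limit of the assay)
- compound 3 `CCC1=C(O)c2c(oc(-c3cccc(C(F)(F)F)c3)cc2=O)C(CC)(CC)C1=O`: 35.7 uM

Compound 3, at 35.7 uM, lies within the scatter of compound 1, at 39.2 uM. Compound 4 `CCC1=C(O)c2c(oc(-c3cccc(OC)c3)cc2=O)C(CC)(CC)C1=O` has methoxy in place of trifluoromethyl on an aromatic carbon. Among the measured compounds shown here, the one measured step is an at least 1.3-fold higher number from compound 1 to compound 2 (0.12 log units; that floor lies within the scatter). It puts methoxy in place of hydrogen on a saturated chain carbon, not on an aromatic carbon, and so bears only loosely on this change. No step beyond the scatter is therefore expected in this assay. The expected step is a 1.1-fold higher number from compound 3 to compound 4 (0.05 log units; within the scatter). The estimated value for compound 4 is 40 uM, with an expected range from 22 uM to 60 uM.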

Compound 4, concentration for half-maximal effect: 13.3 uM
Compound 4: middle estimate off by 3.0-fold (0.48 log units), on the high side; measured number outside the range, below it.
By their numbers in this assay, from the lowest: compound 4; then compounds 3 and 1 (each within the scatter of the next). At a limit, above all of these: compound 2.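

In this assay, this aromatic carbon proves able to move the number: methoxy in place of trifluoromethyl gives a 2.7-fold lower number from compound 3 to compound 4 (0.43 log units; beyond the scatter). Among the compounds shown here, the 3-methoxyphenyl group also separates from 4-methylphenyl, with a 2.9-fold lower number from compound 1 to compound 4 (0.47 log units; beyond the scatter), something the earlier compounds, all close together or at a limit, did not show. The step against 4-(methoxymethyl)phenyl, an at least 3.9-fold lower number from compound 2 to compound 4 (0.59 log units; beyond the scatter), starts from a limit of the assay and not a number: the limit of > 52.4 uM in this assay, at which 1 of the 4 values shown sits.

As far as these compounds go, it stays open whether the lower number belongs to methoxy itself or to where it sits on the ring. From the compounds shown here alone, how an amine or an ethoxy group would read on this same carbon is also open.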